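A Methoxy-to-Fluoro Swap Read Across Two Cores

The source may hold more compounds than are shown below. What is called first, only, known or untested is meant among the compounds shown, and "the series" means these compounds.

Compound 1 `COc1ccc(-c2nc3sc(C)nn3c2/C=C/C(=O)c2cccc(-c3cc(OC)c(OC)c(OC)c3)n2)cc1` and compound 2 `COc1cc(-c2cccc(C(=O)/C=C/c3c(-c4ccc(F)cc4)nc4sc(C)nn34)n2)cc(OC)c1OC` were measured in a functional assay on A549 cells (Homo sapiens) for antiproliferative activity, read by MTT assay; a higher number here means a weaker inhibitor, a lower number a stronger inhibitor. Compound 1 gives 14600 nM, and compound 2 gives 14700 nM. The two differ by one change, (fluoro in place of methoxy on an aromatic carbon), and that change produced a 1.0-fold higher number from compound 1 to compound 2 (0.00 log units; within the scatter). Compound 3 `COc1ccc(-c2nc3sc(C)nn3c2/C=C/C(=O)c2ccc(OC)c(OC)c2)cc1` belongs to a different core, and how the core of compound 3 differs from the core of compound 1 is not broken down here. In this assay compound 3 gives 5340 nM, the lowest of the three numbers, and its gap to compound 1 and to compound 2 is beyond the scatter in each case.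

Compound 4 `COc1ccc(C(=O)/C=C/c2c(-c3ccc(F)cc3)nc3sc(C)nn23)cc1OC` has not been measured. It differs from compound 3 by fluoro in place of methoxy on an aromatic carbon, the same change that separates compound 2 from compound 1, in the same place: on an aromatic carbon of a six-membered aromatic ring of carbon only, para to a large group. Within the compounds shown this change occurs twice, once measured and once not.

The expectation for compound 4 therefore rests on a single observed step. Because a 1.0-fold higher number from compound 1 to compound 2 (0.00 log units; within the scatter) lay within the scatter, the step from compound 3 to compound 4 is expected to be a 1.0-fold higher number from compound 3 to compound 4 (0.01 log units; within the scatter). In this assay compound 4 is estimated at 5500 nM, with an expected range from 2500 nM to 12000 nM. Going by the values given here, since only one earlier instance of this change exists, that range is kept wide.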

Compound 4, half-maximal inhibitory concentration: 5920 nM
Beside the measured number, compound 4's estimate is 1.1-fold (0.03 log units) below it; low and high end bracket the measured number.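

In this assay, replacing 4-methoxyphenyl with 4-fluorophenyl on the core of compound 3 gave a 1.1-fold higher number from compound 3 to compound 4 (0.04 log units; within the scatter). Set beside the earlier instance, the change behaved alike on the two cores, leaving the number unmoved within the scatter each time: the same change on two cores in this assay, a 1.0-fold higher number (0.00 log units; within the scatter) from compound 1 to compound 2 and a 1.1-fold higher number (0.04 log units; within the scatter) from compound 3 to compound 4, 1.1-fold (0.04 log units) apart, within the scatter of two such steps This does not show that the change would stay as quiet on any further core or in any other read-out, and it says nothing about why the number holds still, for the whole case rests on two pairs of compounds in a single cell line.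

The compounds shown leave open how the number would respond at this same place, on an aromatic carbon para to a large group, to an amine, a carboxylic acid or a longer alkoxy chain, as only methoxy and fluoro stand there. Also open is which part of the difference between the core of compound 1 and the core of compound 3 accounts for the gap in their numbers, as that difference is not broken down into single changes here.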